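Benzyl for 3-hydroxyphenyl in a series near its limit

A few compounds are considered here, and "the series" means these few. Any claim that something is new, unique, unknown or untested is made for them only; others in the source may bear on it.

In a functional assay on SK-HEP1 cells (Homo sapiens) for cytotoxicity, read by MTT assay, with a stated time of 48 h (on this read-out higher numbers stand for weaker inhibition and lower numbers for stronger inhibition), compound 1 `C#Cc1cccc(N(C)c2nc(Cl)nc3cc(OC)c(OC)cc23)c1` gives 12300 nM as a measured number.

Compound 2 `COc1cc2nc(Cl)nc(Nc3cccc(O)c3)c2cc1OC` gives > 40000 nM in this assay and this is a limit, not a number.

Compound 3 `COc1cc2nc(Cl)nc(Nc3cccc(Oc4ccc(C#N)cc4)c3)c2cc1OC` gives > 40000 nM in this assay and this too is a limit.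

Compound 2 therefore stands at the limit of > 40000 nM in this assay, at which 2 of the 3 values shown sit, and offers no exact starting point.

The next change leads to compound 4 `COc1cc2nc(Cl)nc(NCc3ccccc3)c2cc1OC` and is benzyl in place of 3-hydroxyphenyl on a nitrogen on an aromatic ring with benzyl entering where 3-hydroxyphenyl leaves.

Among the measured compounds shown here, the one measured step from compound 2 is a step that the two limits leave unreadable from compound 2 to compound 3 and it gives no size to carry over, since it concerns a group on an oxygen on an aromatic ring.

For the measured compounds named here, compound 1 at 12300 nM shows only that a number can be read on this core family, so a modest move is the most that can be expected.

The expected change is an at least 1.2-fold lower number from compound 2 to compound 4 (0.09 log units; that floor lies within the scatter) toward stronger inhibition, if it proves readable at all.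

For compound 4 the estimated value is 32000 nM with an expected range from 12000 nM to 80000 nM and a reading as a limit remains quite possible.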

Compound 4, half-maximal inhibitory concentration: 19800 nM
Beside the measured number, compound 4's estimate is 1.6-fold (0.21 log units) above it; the range from low to high includes it.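

In this assay, benzyl in place of 3-hydroxyphenyl on the nitrogen gives an at least 2.0-fold lower number from compound 2 to compound 4 (0.30 log units; that floor lies within the scatter). This is the only readable step in the set, since the step at the oxygen of compound 2 cannot be read, and its size is only a floor because compound 2 stands at a limit: the limit of > 40000 nM in this assay, at which 2 of the 4 values shown sit.

Compound 4 also shows that a number can be read in this series with 0 hydrogen-bond donors and 0 hydrogen-bond acceptors on the group at this nitrogen.

The compounds shown leave open whether the step follows the loss of the hydroxyl or the change from phenyl to benzyl itself. Unsubstituted phenyl, 2-phenylethyl as a longer chain, and benzyl carrying an amine or a carboxylic acid on its ring would each test this.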